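The source may report more compounds than this note shows. Statements on the series, on what has been measured and on what is new or still open speak of the compounds shown alone.

Compound 1, with the structure `NC(=O)/C=C/c1ccncc1-c1ccc2ccccc2c1`, is the starting point of this account, and its activity was examined in a functional assay on A549 cells (Homo sapiens) for inhibition, read by sulforhodamine B assay, with a stated time of 72 h; a lower number here means a stronger inhibitor of growth, a higher number a weaker inhibitor of growth. In this assay compound 1 gives only a limit, > 10000 nM, and not a number. Compound 2, `CNC(=O)/C=C/c1ccncc1-c1ccc2c(cnn2C)c1`, likewise gives only a limit in this assay, > 10000 nM. Compound 3, `O=C(/C=C/c1ccncc1-c1ccc2cc[nH]c2c1)N1CCOCC1`, also gives only a limit in this assay, > 10000 nM. Compound 1 therefore stands nowhere apart from the others: all three measured values sit at the limit of > 10000 nM in this assay, at which 3 of the 3 values shown sit, and no ordering among them can be drawn. The unmeasured compound 4, `NNC(=O)CCc1ccncc1-c1ccc2ccccc2c1`, differs from compound 1 in one place: 2-(aminocarbamoyl)ethyl in place of 2-carbamoylethenyl on an aromatic carbon. Within the data shown here, no step between measured compounds exists to guide the size of this change. Every measured value sits at the limit of > 10000 nM in this assay, at which 3 of the 3 values shown sit. On that basis compound 4 is expected to remain at or near that limit, and the step that the limit leaves unreadable from compound 1 to compound 4 is expected to be none beyond the scatter. Compound 4 is estimated at 15000 nM in this assay, with a range from 5000 nM to 50000 nM.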

Compound 4, concentration for 50% growth inhibition: > 10000 nM
Compound 4: only a limit was reported; the forecaster's own chance of this, stated with the estimate: 80%; the middle value is on the limit's open side.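

In this assay, among these compounds, compound 1 and compound 4 both give only a limit, so no step between them can be read. The compounds shown leave open how strongly any of them inhibits growth, and which change would bring a value off the limit: the limit of > 10000 nM in this assay, at which 4 of the 4 values shown sit.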